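The source may report more compounds than this note shows. Statements on the series, on what has been measured and on what is new or still open speak of the compounds shown alone.

Compounds measured so far:

- compound 1 `Nc1cc(N)c2nc(-c3ccccc3)c(NCc3ccc(Cl)c(Cl)c3)nc2c1`: 72400 nM
- compound 2 `COc1ccc(CNc2nc3cc(N)cc(N)c3nc2-c2ccccc2)cc1OC`: 64600 nM
- compound 3 `Nc1cc(N)c2nc(-c3ccccc3)c(NCc3ccc(F)cc3)nc2c1`: 53700 nM

All three were tested in a functional assay on TK-10 cells (Homo sapiens) for inhibition, read by sulforhodamine B assay, with a stated time of 48 h; on this read-out lower numbers stand for higher toxicity in this test and higher numbers for lower toxicity in this test. The three numbers cannot be told apart: the changes at the benzyl aryl ring gave a 1.1-fold lower number from compound 1 to compound 2 (0.05 log units; within the scatter), a 1.3-fold lower number from compound 1 to compound 3 (0.13 log units; within the scatter) and a 1.2-fold lower number from compound 2 to compound 3 (0.08 log units; within the scatter), so compound 3 stands within the scatter of both compound 2 and compound 1, and nothing separates them.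

Compound 4 `Nc1cc(N)c2nc(-c3ccccc3)c(Sc3ccc(F)cc3)nc2c1` differs from compound 3 in one place: (4-fluorophenyl)sulfanyl in place of (4-fluorobenzyl)amino on an aromatic carbon. For the measured compounds named here, none of the measured steps bears on this change; each of them only swaps one aryl substituent pattern for another while the (4-fluorobenzyl)amino link stays, and each of them was within the scatter. There is therefore no measured basis for a step in either direction, and the expectation for compound 4 in this assay is a number close to that of compound 3, with a wide range to cover the unknown effect of the new link. The estimate for compound 4 is 55000 nM, between 18000 nM and 160000 nM, which corresponds to an expected step of a 1.0-fold higher number from compound 3 to compound 4 (0.01 log units; within the scatter).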

Compound 4, concentration lethal to 50% of the cells: < 100000 nM
Compound 4 gave a limit, no number; the forecaster's own chance of this, stated with the estimate: 10%; the middle value lies beyond the limit too.
By their numbers in this assay, from the lowest: compounds 3, 2 and 1 (each within the scatter of the next).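

In this assay compound 4 gives < 100000 nM, which is a limit and not a number. For the compounds shown here, no step from compound 3 to compound 4 can therefore be read. The compounds shown leave open whether (4-fluorophenyl)sulfanyl in place of (4-fluorobenzyl)amino changes the read-out at all, and in which direction.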